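The compounds below may be only part of what the source reports. "The series", "measured", "known", "first", "only" and "open" are said of these compounds alone.

Compound 1 `O=C(/C=C/c1ccccc1)NCc1ccc(Cl)cc1Cl` gives 0% in a functional assay on the whole organism for inhibition, with Brassica rapa subsp. chinensis as the target, with a stated time of 3 days, tested at 100 ppm; on this read-out lower numbers stand for less inhibition of growth and higher numbers for more inhibition of growth at the one concentration tested.
Compound 2 `Cc1ccc(C(C)C)c(OC(=O)/C=C/c2ccc(Cl)cc2Cl)c1` gives 33%.
Compound 3 `Cc1ccc(C(C)C)c(OC(=O)/C=C/c2ccc(Cl)cc2)c1` gives 36%.

Compounds 2 and 3 share one core, while compound 1 is built on another; the difference between the core of compound 1 and the core of compound 2 is not broken down here. Compound 1 has the lowest number of the three, and both compound 2 and compound 3 lie beyond the scatter above it. Within the shared core of compounds 2 and 3 one change is made, (hydrogen in place of chloro on an aromatic carbon), and it gave a number 3 percentage points higher from compound 2 to compound 3 (within the scatter). The same change is now made on compound 1, giving compound 4 `O=C(/C=C/c1ccccc1)NCc1ccc(Cl)cc1`, which is still to be measured: hydrogen in place of chloro on an aromatic carbon. Among the compounds shown this change occurs twice. The step from compound 1 to compound 4 is expected to be a number 2 percentage points higher from compound 1 to compound 4 (within the scatter), because a number 3 percentage points higher from compound 2 to compound 3 (within the scatter) stayed within the scatter and compound 1 already sits at the bottom of the read-out. Compound 4 is therefore estimated at 2%, with a range from 0% to 12%.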

Compound 4, percent growth inhibition at one concentration: 6%
Estimate against measurement, compound 4: 4 percentage points below; the measured number falls inside the stated range.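

In this assay, among these compounds, hydrogen in place of chloro on an aromatic carbon gives a number 6 percentage points higher from compound 1 to compound 4 (within the scatter) and so, on this core as well, produces no step that can be told apart from ordinary repeat-to-repeat variation. The two cores agree on this change: the same change on two cores in this assay, a number 3 percentage points higher (within the scatter) from compound 2 to compound 3 and a number 6 percentage points higher (within the scatter) from compound 1 to compound 4, 3 percentage points apart, within the scatter of two such steps. This shows that, in these two pairs, the change carried over from one core to the other as a step too small to read, but two pairs are thin support, and neither shows what would happen on a further core or on one where the change moves the number clearly.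

The compounds shown leave open what a different group at this place on the ring would do, such as a methyl group, a methoxy group or an amine. They also leave open whether this change would still read the same at a concentration other than the single one tested.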